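Reshaping the amide end of a bis-sulfonamide piperidine series

This account rests on a few compounds, and the source may have more. Where it says the series, first, only, none or still open, it means among the compounds named here.

Three measured compounds share one core. In a functional assay on MIA PaCa-2 cells (Homo sapiens) for inhibition, read by MTT assay, with a stated time of 7 days (a lower number here means a stronger inhibitor, a higher number a weaker inhibitor), compound 1 `CCN(CC)S(=O)(=O)c1ccc(S(=O)(=O)N2CCC[C@@H](C(=O)N[C@@H]3CCN(C(=O)OC(C)(C)C)C3)C2)cc1` gives 200 nM, compound 2 `CCN(CC)S(=O)(=O)c1ccc(S(=O)(=O)N2CCC[C@@H](C(=O)NC3CN(C(=O)C4CC4)C3)C2)cc1` gives 2800 nM, and compound 3 `CCOC(=O)[C@@H]1CCCN(S(=O)(=O)c2ccc(S(=O)(=O)N(CC)C(C)C)cc2)C1` gives 1000 nM, so compound 2 stands highest of the three. Compound 4 `CCN(CC)C(=O)[C@@H]1CCCN(S(=O)(=O)c2ccc(S(=O)(=O)N(CC)CC)cc2)C1` is not yet measured; it differs from compound 2 by diethylamino in place of (1-(cyclopropylcarbonyl)azetidin-3-yl)amino on a carbonyl carbon. Going by the values given here, one measured step bears on this site: a 14-fold higher number from compound 1 to compound 2 (1.15 log units; beyond the scatter), showing that the group on the amide-type nitrogen matters. Compound 3, bearing a small ester in this region, sits below compound 2. Compound 4 is therefore expected to fall below compound 2, with a 2.8-fold lower number from compound 2 to compound 4 (0.45 log units; beyond the scatter) estimated, giving an expected value of 1000 nM within a range of 300 nM to 4000 nM.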

Compound 4, half-maximal inhibitory concentration: 6400 nM
Beside the measured number, compound 4's estimate is 6.4-fold (0.81 log units) below it; the measured number lies above the stated range.
By their numbers in this assay, from the lowest: compound 1; then compound 3; then compound 2; then compound 4.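

In this assay, diethylamino in place of (1-(cyclopropylcarbonyl)azetidin-3-yl)amino on a carbonyl carbon gives a 2.3-fold higher number from compound 2 to compound 4 (0.36 log units; beyond the scatter). The earlier step exchanged one ring-bearing group for another on an amide-type nitrogen; this one shows that a group with no ring and no hydrogen-bond donor also gives a higher number, beyond the scatter. No available evidence explains this change. Open, from the compounds shown here alone, is whether ethylamino, which keeps the amide hydrogen without any ring, would separate these two differences, and whether a free azetidin-3-ylamino group would behave differently.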